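Naphthalen-2-yl for Methoxyphenyl on a Weak Core

This account rests on a few compounds, and the source may have more. Where it says the series, first, only, none or still open, it means among the compounds named here.

Compound 1 `COc1ccc(C2=NN(C3=NC(=O)/C(=C4\C(=O)Nc5ccc(Br)cc54)S3)C(c3ccc(OC)cc3)C2)cc1` gives 200 nM in a functional assay on cells (Cancer cell lines, Homo sapiens) for cytotoxicity, read by sulforhodamine B assay, with a stated time of 48 h; a lower number here means a stronger inhibitor of growth, a higher number a weaker inhibitor of growth.
Compound 2 `COc1ccc(C2CC(c3ccc4ccccc4c3)=NN2C2=NC(=O)/C(=C3\C(=O)Nc4ccc(Br)cc43)S2)cc1` gives 64 nM in this assay.
Compound 3 `COc1ccc(C2=NN(C3=NC(=O)/C(=C4\C(=O)Nc5ccccc54)S3)C(c3ccc(Cl)cc3)C2)cc1` gives 100000 nM in this assay.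

Compound 2 differs from compound 1 by naphthalen-2-yl in place of 4-methoxyphenyl on a carbon with a double bond to nitrogen. That change gave a 3.1-fold lower number from compound 1 to compound 2 (0.49 log units; beyond the scatter). Compound 3 stands far above both; how its core differs from that of compound 1 is not broken down here.

Compound 4 `O=C1N=C(N2N=C(c3ccc4ccccc4c3)CC2c2ccc(Cl)cc2)S/C1=C1/C(=O)Nc2ccccc21` has not been measured. It differs from compound 3 by naphthalen-2-yl in place of 4-methoxyphenyl on a carbon with a double bond to nitrogen. The surroundings are not word for word the same as in the earlier pair: here the ring atom two ring bonds away bears a 4-chlorophenyl group, there a 4-methoxyphenyl group, so this is the same kind of change rather than the same change.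

For compound 4 a step of about the same size as a 3.1-fold lower number from compound 1 to compound 2 (0.49 log units; beyond the scatter) is expected, so a 2.9-fold lower number from compound 3 to compound 4 (0.46 log units; beyond the scatter), because compound 3 starts from 100000 nM and a move of that size still leaves a weak compound. The estimate for compound 4 in this assay is 35000 nM, with a likely range from 8000 nM to 100000 nM.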

Compound 4, concentration for 50% growth inhibition: 400 nM
Estimate against measurement, compound 4: 88-fold (1.94 log units) above; measured number outside the range, below it.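

In this assay, putting naphthalen-2-yl in place of 4-methoxyphenyl gave a 250-fold lower number from compound 3 to compound 4 (2.40 log units; beyond the scatter), a large step that turns a very weak compound into a far stronger one. The change lowered the number on both cores, so its direction carried over, but its size did not: the same change on two cores in this assay, a 3.1-fold lower number (0.49 log units; beyond the scatter) from compound 1 to compound 2 and a 250-fold lower number (2.40 log units; beyond the scatter) from compound 3 to compound 4, 80-fold (1.90 log units) apart, beyond the scatter of two such steps. This does not show which feature of the cores sets the size of the step, since the core of compound 1 and the core of compound 3 differ from each other in more than one place, and two pairs cannot give a general rule for the series.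

A pair differing only in the 4-chlorophenyl or 4-methoxyphenyl group, with everything else the same, would be needed to separate those differences. The compounds shown also leave open what a group other than these two aromatic ones, such as a small methyl or a ring carrying an amine or a carboxylic acid, would do on the same carbon.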